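Thiourea-bearing Analogue of Compound 1 in HeLa Proliferation

The compounds below may be only part of what the source reports. "The series", "measured", "known", "first", "only" and "open" are said of these compounds alone.

Measured compounds:
compound 1, `NC(=O)c1c(NC(=O)c2ccccc2Cl)sc2c1CCNC2`, 45000 nM
compound 2, `NC(=O)c1c(NC(=O)c2ccccc2F)sc2c1CCN(Cc1c(Cl)cccc1Cl)C2`, 33000 nM
compound 3, `NC(=O)c1c(NC(=O)c2cccc([N+](=O)[O-])c2)sc2c1CCN(Cc1c(Cl)cccc1Cl)C2`, 46100 nM

Of the compounds shown here, three sharing one core have been tested in a functional assay on HeLa cells (Homo sapiens) for antiproliferative activity, with a stated time of 24 h; on this read-out lower numbers stand for stronger inhibition and higher numbers for weaker inhibition. Compound 1 gives 45000 nM and stands second highest of the three numbers; its nearest neighbour is compound 3, its furthest compound 2, and both gaps lie within the scatter. Going by the values given here, the only single-point step recorded, a 1.4-fold higher number from compound 2 to compound 3 (0.15 log units; within the scatter), also stays within the scatter, so nothing measured so far moves the read-out beyond noise.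

Compound 4, `NC(=O)c1c(NC(=O)c2ccccc2Cl)sc2c1CCN(C(=S)Nc1ccccc1F)C2`, is not yet measured. It differs from compound 1 by a group of 10 heavy atoms (7 carbon, 1 nitrogen, 1 fluorine, 1 sulfur; one six-membered aromatic ring of carbon only) in place of a hydrogen atom, on an amine nitrogen in a ring. Among the compounds with values here, no measured step touches this position in isolation; compounds 2 and 3 differ from compound 1 in more than one place, and their values sit within the scatter of compound 1. There is therefore no basis for expecting a step beyond the scatter in this assay in either direction. Compound 4 is expected to give about 30000 nM, between 8000 nM and 100000 nM, which means an expected step of a 1.5-fold lower number from compound 1 to compound 4 (0.18 log units; within the scatter).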

Compound 4, half-maximal inhibitory concentration: 28700 nM
Estimate against measurement, compound 4: 1.0-fold (0.02 log units) above; measured number inside the range.
By their numbers in this assay, from the lowest: compounds 4, 2, 1 and 3 (each within the scatter of the next).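

In this assay, going by these compounds alone, the exchange of a hydrogen atom for a group of 10 heavy atoms, with one six-membered aromatic ring of carbon only, on an amine nitrogen in a ring gives a 1.6-fold lower number from compound 1 to compound 4 (0.20 log units; within the scatter), and this is the first reading of that position on its own. The step shows that this nitrogen can carry a group of this size, including a sulfur atom, a fluorine atom and a carbon-only aromatic ring, without the antiproliferative read-out leaving the scatter, so the hydrogen there is not required to hold the number at this level. No measurement is at hand that would explain this result.

The compounds shown leave open whether any group on this nitrogen can move the number beyond the scatter in either direction, for example a urea with oxygen in place of the sulfur, or a longer chain ending in an amine. They also leave open what the fluorine contributes to the entering group, since a plain phenyl ring or a chlorine atom in its place would be needed to read that.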